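Methyl for Methoxy on a Weakly Cytotoxic Scaffold

The source may report more compounds than this note shows. Statements on the series, on what has been measured and on what is new or still open speak of the compounds shown alone.

Within the data shown here, compound 1, with the structure `CNC(=O)c1cc(Oc2ccc(NC(=O)c3cc(-c4ccc(OC)cc4)ncn3)cc2F)ccn1`, is the only member of this small group to give a number: in a functional assay on MCF7 cells (Homo sapiens) for cytotoxicity, read by MTT assay, with a stated time of 72 h (a higher number here means a weaker inhibitor, a lower number a stronger inhibitor), compound 1 gives 46200 nM. Compound 2, `CNC(=O)c1cc(Oc2ccc(NC(=O)c3cc(-c4ccc(F)cc4)ncn3)cc2)ccn1`, reaches only the limit of the assay, > 100000 nM. Compound 3, `CNC(=O)c1cc(Oc2ccc(NC(=O)c3nccc(-c4ccc(OC)cc4)n3)cc2F)ccn1`, likewise sits at the limit, > 100000 nM. The picture is therefore (the limit of > 100000 nM in this assay, at which 2 of the 3 values shown sit), with compound 1 alone carrying a measured value, and even that value marks a weak inhibitor.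

Compound 4, `CNC(=O)c1cc(Oc2ccc(NC(=O)c3cc(-c4ccc(C)cc4)ncn3)cc2F)ccn1`, has not been measured. It differs from compound 1 in one place: methyl in place of methoxy on an aromatic carbon. Among the measured compounds shown here, no pair of measured compounds differs in a single place, so no measured step shows how large such a change tends to be here. With compound 1 at 46200 nM, the change to compound 4 is expected to stay within the usual scatter, leaning if anything toward a weaker inhibitor. Compound 4 is therefore estimated at 60000 nM, between 25000 nM and 150000 nM. That estimate means a step of a 1.3-fold higher number from compound 1 to compound 4 (0.11 log units; within the scatter).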

Compound 4, half-maximal inhibitory concentration: 19200 nM
The estimate for compound 4 lay 3.1-fold (0.49 log units) above the measured number; the measured number lies below the stated range.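

In this assay, among these compounds, a 2.4-fold lower number from compound 1 to compound 4 (0.38 log units; beyond the scatter) is the first step that can be read in this group, and it shows that the group at this place on the ring can shift the number beyond the scatter. At this carbon, para to a large group, methyl in place of methoxy gives the stronger inhibitor, although compound 4 remains a weak one. Nothing measured here gives a reason for the direction of this step.

The compounds shown leave open how a plain hydrogen, an amine or a longer chain such as propyl would read at this place. They also leave open whether the same change would carry over to compound 3, whose value is only a limit of the assay.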